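From fluoro to methyl: what to expect of compound 4

The source may hold more compounds than are shown below. What is called first, only, known or untested is meant among the compounds shown, and "the series" means these compounds.

Of the compounds shown here, three have been measured in a functional assay on MCF7 cells (Homo sapiens) for antiproliferative activity, read by sulforhodamine B assay, with a stated time of 48 h; a higher number here means a weaker inhibitor, a lower number a stronger inhibitor. Compound 1 (`O=C(CCCCCCN1C(=O)/C(=N\O)c2cc(F)ccc21)NO`) gives 1550 nM, compound 2 (`Cc1ccc2c(c1)/C(=N/O)C(=O)N2CCCCCCC(=O)NO`) gives 1190 nM, and compound 3 (`CO/N=C1/C(=O)N(CCCCCCC(=O)NO)c2ccc(F)cc21`) gives 2420 nM. Compound 3 therefore stands within the scatter of compound 1, while its number lies above that of compound 2 by a gap just beyond the scatter.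

The next compound, compound 4 (`CO/N=C1/C(=O)N(CCCCCCC(=O)NO)c2ccc(C)cc21`), departs from compound 3 in a single place: methyl in place of fluoro on an aromatic carbon. This is methyl in place of fluoro on an aromatic carbon.

Within the data shown here, one measured step bears on this change, the same exchange of groups, seen as a 1.3-fold lower number from compound 1 to compound 2 (0.11 log units; within the scatter). That step is small, and it comes from a pair that differs from compound 3 elsewhere in the structure. Among the measured compounds shown here, it is also the only evidence available, so it supports no more than a slight lean towards a lower number, and no shift beyond the scatter is expected in this assay.

The estimated step is a 1.3-fold lower number from compound 3 to compound 4 (0.11 log units; within the scatter). For compound 4 the estimated value is 1900 nM, with an expected range from 1100 nM to 3300 nM.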

Compound 4, half-maximal inhibitory concentration: 16700 nM
Compound 4: the middle estimate sits 8.8-fold (0.94 log units) below what was measured; measured number outside the range, above it.
By their numbers in this assay, from the lowest: compounds 2, 1 and 3 (each within the scatter of the next, the first and the last beyond it); then compound 4.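

Methyl in place of fluoro on this aromatic carbon proves not to be a quiet exchange in this assay: it gives a 6.9-fold higher number from compound 3 to compound 4 (0.84 log units; beyond the scatter), whereas the earlier pair showed no change beyond the scatter. The effect of the exchange therefore depends on the rest of the molecule, and compounds 3 and 4 differ from compounds 1 and 2 in carrying a methyl rather than a hydrogen on the oxime oxygen: the same change on two cores in this assay, a 1.3-fold lower number (0.11 log units; within the scatter) from compound 1 to compound 2 and a 6.9-fold higher number (0.84 log units; beyond the scatter) from compound 3 to compound 4, 9.0-fold (0.95 log units) apart, beyond the scatter of two such steps Across these four compounds, the group on this carbon matters much more when the oxime oxygen bears a methyl, so the step seen in the first pair cannot be carried over to the second.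

On these data alone, whether chloro, methoxy or a plain hydrogen on the same carbon would stay close to compound 3 or fall with compound 4 remains open. It is also open whether the same exchange would give a step of this size with an ethyl or a benzyl on the oxime oxygen, and the compounds shown do not say why the two pairs part.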